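Working notes: from compound 1 to compound 4

The source may report more compounds than this note shows. Statements on the series, on what has been measured and on what is new or still open speak of the compounds shown alone.

All numbers below come from an assay on isolated protein for inhibition of 2-Hydroxyacid oxidase 2 (Homo sapiens), tested at 1 uM; a higher number here means a stronger effect of the compound at the concentration tested, a lower number a weaker effect.

- compound 1, `Cc1n[nH]c(C(=O)O)c1Cc1cccc(-c2cccc(F)c2)c1`: 20%
- compound 2, `Cc1n[nH]c(C(=O)O)c1Cc1ccc(Oc2ccccc2)cc1`: 10%
- compound 3, `Cc1c(Cc2cccc(-c3ccc(F)cc3)c2)c(C(=O)O)nn1C`: 2%

Compound 1 holds the highest of the three numbers. Compound 2 sits lower by a gap within the usual scatter, so the two cannot be ordered against each other. Compound 3 sits below compound 1 by a gap beyond the scatter, so compound 1 does stand above compound 3 in this assay . No pair among these three differs in a single place, so no step between measured compounds is available.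

Compound 4, `Cc1n[nH]c(C(=O)O)c1Cc1cccc(C#N)c1`, is not yet measured. It differs from compound 1 in one place: cyano in place of 3-fluorophenyl on an aromatic carbon.

Among the compounds with values here, the measured set gives no direct guide to this kind of change, since no two measured compounds differ by a single group. With the whole six-membered ring gone and only a two-atom group in its place, the expectation is a downward step, and the estimated step of a number 13 percentage points lower from compound 1 to compound 4 (beyond the scatter) is taken as larger than the scatter. Compound 4 is therefore expected to give 7% in this assay , with a range from 0% to 18%.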

Compound 4, a percentage reported as inhibition, at one concentration (the size of the read-out at that concentration, not a potency): 6%
Compound 4: the middle estimate sits 1 percentage points above what was measured, and the stated range covers the measured number.
By their numbers in this assay, from the lowest: compounds 3, 4, 2 and 1 (each within the scatter of the next, the first and the last beyond it).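

Working from the first single-place step in the series, in this assay the change from 3-fluorophenyl to cyano gives a number 14 percentage points lower from compound 1 to compound 4 (beyond the scatter). Within the data shown here, this shows that the read-out at this position, on an aromatic carbon meta to a large group, depends on which group is present: the earlier compounds differed in more than one place and could not show this. The step is read at one concentration only, so it records a change in the size of the read-out and not in potency, and no measurement at hand speaks to the reason for it.

This single step combines several changes, since a group of 7 heavy atoms with a six-membered aromatic ring gives way to one of 2 heavy atoms with no ring and a hydrogen-bond acceptor, and the compounds shown do not separate these changes. A plain phenyl, a pyridine ring or a methoxy group at the same position would help show whether the ring, the fluorine or the group's size tracks with the read-out.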